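The source may report more compounds than this note shows. Statements on the series, on what has been measured and on what is new or still open speak of the compounds shown alone.

Among the compounds measured so far, compound 2 `NC(=O)C1CCCN(C(=O)CN2CN(c3ccccc3)C3(CCN(C(=O)c4ccc(C5CCCCC5)cc4)CC3)C2=O)C1` stands at the high end: in an assay on HEK293 cells for displacement of a labelled ligand from NPC1-like intracellular cholesterol transporter 1 (Homo sapiens) (on this read-out higher numbers stand for weaker inhibition and lower numbers for stronger inhibition), compound 2 gives 3100 nM. Among the compounds with values here, its only neighbour on the numbers is compound 1 `CC1(C)CC(OC(=O)CN2CN(c3ccccc3)C3(CCN(C(=O)c4ccc(C5CCCCC5)cc4)CC3)C2=O)CC(C)(C)N1`, which in this assay gives 600 nM. Within the data shown here, the single measured step, a 5.2-fold higher number from compound 1 to compound 2 (0.71 log units; beyond the scatter), exchanged (2,2,6,6-tetramethylpiperidin-4-yl)oxy for 3-carbamoylpiperidin-1-yl on a carbonyl carbon.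

Compound 3 `O=C(CN1CN(c2ccccc2)C2(CCN(C(=O)c3ccc(C4CCCCC4)cc3)CC2)C1=O)NCCCCO` now alters that same position: (4-hydroxybutyl)amino in place of 3-carbamoylpiperidin-1-yl on a carbonyl carbon. The step from compound 1 to compound 2 is the only one that touches this carbonyl carbon, and it was modest in size; but both groups involved there carried a six-membered ring, whereas (4-hydroxybutyl)amino is an open chain, so that step offers only a loose guide. Among the measured compounds shown here, with no closer precedent, the expectation for compound 3 is a change of uncertain direction, most likely one that stays near or somewhat below the number of compound 2, giving an expected step of a 1.6-fold lower number from compound 2 to compound 3 (0.19 log units; within the scatter). Compound 3 is therefore estimated at 2000 nM in this assay, with a plausible range from 600 nM to 7000 nM.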

Compound 3, half-maximal inhibitory concentration: 10300 nM
Estimate against measurement, compound 3: 5.2-fold (0.71 log units) below; the measured number lies above the stated range.
By their numbers in this assay, from the lowest: compound 1; then compound 2; then compound 3.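

In this assay, replacing the ring-bearing 3-carbamoylpiperidin-1-yl with the open (4-hydroxybutyl)amino chain on this carbonyl carbon gives a 3.3-fold higher number from compound 2 to compound 3 (0.52 log units; beyond the scatter), so the position also responds to a change from a ring to a chain, and not only to the exchange between two ring-bearing groups seen earlier. Across the three compounds, the largest step is a 17-fold higher number from compound 1 to compound 3 (1.23 log units; beyond the scatter), which places the open chain at the weak end of this small set and shows that the groups tried on this carbonyl carbon span a wide range of inhibition. Nothing available bears on why the chain gives the highest number.

The compounds shown leave open whether the loss follows from the missing ring, from the terminal hydroxyl or from the chain length, which a plain butylamino group, a longer 6-hydroxyhexylamino chain or an unsubstituted piperidin-1-yl group would help to separate. They also leave open how much of the gap to compound 1 belongs to its ester oxygen and how much to its 2,2,6,6-tetramethylpiperidin-4-yl ring, a question that the matching amide, (2,2,6,6-tetramethylpiperidin-4-yl)amino, would address.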